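The source may report more compounds than this note shows. Statements on the series, on what has been measured and on what is new or still open speak of the compounds shown alone.

Measured so far:
compound 1 `Oc1ccc(-c2cc(-c3ccccc3C(F)(F)F)cc(-c3ccc(O)cc3)n2)cc1` — > 50000 nM, a limit of the assay
compound 2 `Oc1ccc(-c2cc(-c3ccccc3OC(F)(F)F)cc(-c3ccccc3O)n2)cc1` — 9820 nM

In a functional assay on HCT-15 cells (Homo sapiens) for inhibition (on this read-out higher numbers stand for weaker inhibition and lower numbers for stronger inhibition), compound 2 gives 9820 nM. This is the only number shown in the series. Compound 1 in this assay reaches only a limit, > 50000 nM. Compound 1 thus sits at the limit of > 50000 nM in this assay, at which 1 of the 2 values shown sits.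

Compound 3 `Oc1ccc(-c2cc(-c3ccccc3OC(F)(F)F)cc(-c3ccc(O)cc3)n2)cc1` is the next target. It differs from compound 2 by 4-hydroxyphenyl in place of 2-hydroxyphenyl on an aromatic carbon. Among the measured compounds shown here, no step between two measured compounds is available to size this change. Compound 3 carries the same pair of 4-hydroxyphenyl groups as compound 1, and compound 1 gives only a limit, > 50000 nM. The step of a 3.1-fold higher number from compound 2 to compound 3 (0.49 log units; beyond the scatter) is therefore expected to weaken inhibition beyond the scatter, with a real chance that compound 3 itself reports only a limit. Compound 3 is estimated at 30000 nM, between 10000 nM and 90000 nM.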

Compound 3, half-maximal inhibitory concentration: 7760 nM
Compound 3: middle estimate off by 3.9-fold (0.59 log units), on the high side, outside the stated range (below it).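

In this assay, 4-hydroxyphenyl in place of 2-hydroxyphenyl, on the carbon next to the ring nitrogen, gives a 1.3-fold lower number from compound 2 to compound 3 (0.10 log units; within the scatter), so this swap shows no effect here while the trifluoromethoxy group is present. Trifluoromethoxy in place of trifluoromethyl on an aromatic carbon gives an at least 6.4-fold lower number from compound 1 to compound 3 (0.80 log units; beyond the scatter), the only step beyond the scatter among those shown, which places the visible difference at that group and not at the hydroxyphenyl swap. Compound 1 is a limit, so that step gives only a bound on the size of the change: the limit of > 50000 nM in this assay, at which 1 of the 3 values shown sits.

As far as these compounds go, whether the hydroxyphenyl swap is equally silent with trifluoromethyl on the core remains open. Also open, from the compounds shown here alone, is how the series responds when a hydroxyl is replaced by a methoxy group or an amine.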